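The compounds below may be only part of what the source reports. "The series", "measured", "known", "first", "only" and "open" are said of these compounds alone.

In an ADME assay on microsomes from liver (Rattus norvegicus) for metabolic stability (a higher number here means that the compound lasts longer, a lower number that the compound disappears faster), compound 1 `CC(C)C(Cc1ncc[nH]1)c1ccc(-c2ccc3cccc(F)c3c2)[nH]c1=O` gives < 0.0667 h, and this is a limit of the assay, not a number. Compound 2 `CCn1ncc2c(F)cc(-c3ccc(C(CC)(CC)c4nnc(C)[nH]4)c(=O)[nH]3)cc21` gives > 3 h, which is also a limit. Compound 1 thus stands at the low end of the values seen so far. Compound 4 `CC(C)C(Nc1nccs1)c1ccc(-c2ccc3cccc(F)c3c2)[nH]c1=O` keeps the core of compound 1 but carries (1,3-thiazol-2-yl)amino in place of (1H-imidazol-2-yl)methyl on a saturated chain carbon bound to an aromatic carbon and a saturated chain carbon. A short half-life is expected to persist, as compound 3 `CC(C)[C@H](C[C@H]1CCNC1=O)c1ccc(-c2ccc3cccc(F)c3c2)[nH]c1=O`, with that same core, reaches only 0.227 h. The expected step of an at least 1.0-fold higher number from compound 1 to compound 4 (0.02 log units; that floor lies within the scatter) is small, not clearly beyond the scatter. For compound 4 the estimate is 0.07 h, with an expected range of 0.04 h to 0.2 h.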

Compound 4, half-life: 0.07 h
Estimate against measurement, compound 4: no gap at the digits printed; low and high end bracket the measured number.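

In this assay, placing (1,3-thiazol-2-yl)amino in place of (1H-imidazol-2-yl)methyl on this saturated chain carbon gives an at least 1.0-fold higher number from compound 1 to compound 4 (0.02 log units; that floor lies within the scatter). Compound 4 gives 0.07 h, so this position now has a measured number rather than a limit. The value of compound 1 is a limit of the assay, and the step is therefore only a floor: the limit of < 0.0667 h in this assay, at which 1 of the 4 values shown sits.

On these data alone, the true size of the step from the imidazole group to the thiazole group stays open. So does whether a carboxylic acid or a simple amine on this carbon would give a longer half-life on the shared core.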